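The compounds below may be only part of what the source reports. "The series", "measured", "known", "first", "only" and "open" are said of these compounds alone.

Measured so far:
compound 1 `COc1ccc(C(=NNC(=O)NNC(=O)NCCCC(C)Nc2cc(OC)cc3cccnc23)c2ccc(OC)cc2)cc1` — 50000 nM
compound 2 `COc1cc(NC(C)CCCNC(=O)NNC(=O)N(CCO)CCO)c2ncccc2c1` — > 250000 nM
compound 3 `O=C(NC(c1ccccc1)c1ccc(Cl)cc1)NC(c1ccccc1)c1ccc(Cl)cc1` — > 250000 nM

In a functional assay on HeLa cells (Homo sapiens) for inhibition, read by MTT assay, with a stated time of 4 days (a lower number here means a stronger inhibitor, a higher number a weaker inhibitor), compound 2 gives > 250000 nM, which is a limit of the assay and not a number. Compound 3 gives > 250000 nM, likewise a limit. Among the measured compounds shown here, compound 1 gives 50000 nM, the only measured number among the three. Compound 2 therefore stands at the limit of > 250000 nM in this assay, at which 2 of the 3 values shown sit, and cannot be ordered against compound 3 on these data.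

Compound 4 `COc1cc(NC(C)CCCNC(=O)NNC(=O)NCCCCCO)c2ncccc2c1` carries (5-hydroxypentyl)amino in place of bis(2-hydroxyethyl)amino on a carbonyl carbon. For the measured compounds named here, no step between measured compounds bears on this change, so its size and direction are not set by anything here; the expected step is an at least 1.2-fold lower number from compound 2 to compound 4 (0.09 log units; that floor lies within the scatter), not clearly beyond the scatter, and a second limit is a real possibility. Compound 4 is expected near 200000 nM, in a range from 60000 nM to 600000 nM.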

Compound 4, half-maximal inhibitory concentration: >= 250000 nM
Compound 4: only a limit was reported (the forecaster's own chance of this, stated with the estimate: 60%); at least 1.2-fold (0.09 log units) between middle value and limit.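

Compound 2 and compound 4 both end at limits of the assay, not numbers, so no new step can be read between them. Left open is whether (5-hydroxypentyl)amino in place of bis(2-hydroxyethyl)amino on a carbonyl carbon shifts the read-out at all, and in which direction.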